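A few compounds are considered here, and "the series" means these few. Any claim that something is new, unique, unknown or untested is made for them only; others in the source may bear on it.

The series shares the core of compound 1 `Cc1ccccc1CN1CCc2c(sc(NC(=O)c3ccccc3Cl)c2C(N)=O)C1`; in a functional assay on HL-60 cells (Homo sapiens) for antiproliferative activity, with a stated time of 24 h (a lower number here means a stronger inhibitor, a higher number a weaker inhibitor), compound 1 reports only a limit of the assay, > 50000 nM. Compound 2 `NC(=O)c1c(NC(=O)c2ccccc2Cl)sc2c1CCN(C(=S)Nc1ccccc1F)C2` gives 4970 nM, and compound 3 `NC(=O)c1c(NC(=O)c2ccccc2Cl)sc2c1CCN(C(=S)Nc1ccccc1C(F)(F)F)C2` gives 10600 nM, the higher of the two numbers in this assay. The measured steps are an at least 10-fold lower number from compound 1 to compound 2 (1.00 log units; beyond the scatter) and a 2.1-fold higher number from compound 2 to compound 3 (0.33 log units; beyond the scatter). Compound 4 `CSc1ccccc1NC(=S)N1CCc2c(sc(NC(=O)c3ccccc3Cl)c2C(N)=O)C1` differs from compound 3 by methylsulfanyl in place of trifluoromethyl on an aromatic carbon. Within the data shown here, only the step from compound 2 to compound 3 changes the same aromatic carbon, and that step was modest, so no large move is expected here; methylsulfanyl is not fluoro, so the lower number of compound 2 is not assumed to return. Compound 4 is expected at 8000 nM, between 3000 nM and 25000 nM. That estimate means an expected step of a 1.3-fold lower number from compound 3 to compound 4 (0.12 log units; within the scatter).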

Compound 4, half-maximal inhibitory concentration: 14600 nM
The estimate for compound 4 lay 1.8-fold (0.26 log units) below the measured number; the measured number falls inside the stated range.
By their numbers in this assay, from the lowest: compound 2; then compounds 3 and 4 (each within the scatter of the next). At a limit, above all of these: compound 1.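

In this assay, methylsulfanyl and trifluoromethyl on this aromatic carbon are not separated: a 1.4-fold higher number from compound 3 to compound 4 (0.14 log units; within the scatter). Fluoro remains apart from methylsulfanyl, with a 2.9-fold higher number from compound 2 to compound 4 (0.47 log units; beyond the scatter), so among the groups shown at this position, only compound 2 stands clear of the other two. The change on the amine nitrogen in a ring gives an at least 3.4-fold lower number from compound 1 to compound 4 (0.53 log units; beyond the scatter), which is a bound and not a measured size: the limit of > 50000 nM in this assay, at which 1 of the 4 values shown sits.

As far as these compounds go, whether the lower number of compound 2 belongs to fluoro alone stays open. Chloro, hydroxyl or an amine on this aromatic carbon would test that.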